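Removing a fluorine from the pyridine of compound 3

The compounds below may be only part of what the source reports. "The series", "measured", "known", "first", "only" and "open" are said of these compounds alone.

The measured compounds are compound 1 `CC1CN(C(=O)Nc2cc(F)c(F)c(F)c2)Cc2c(N3CC(C#N)CC3=O)cnn21` with 115000 nM, compound 2 `O=C1CC(c2cnco2)CN1c1cnn2c1CN(C(=O)Nc1cc(F)c(F)c(F)c1)C(C1CC1)C2` with 139000 nM, and compound 3 `O=C1CC(c2ccc(F)cn2)CN1c1cnn2c1CN(C(=O)Nc1cc(F)c(F)c(F)c1)C(C1CC1)C2` with 38500 nM, all in a toxicity assay on HepG2 2.2.15 cells (Homo sapiens) for cytotoxicity, read by CellTiter-Glo; a higher number here means that more compound is tolerated, a lower number that less compound is tolerated.

Compound 3 stands lowest of the three numbers in this assay: compound 1 and compound 2 both stand higher, each beyond the scatter. For the measured compounds named here, the only measured step within this set is a 3.6-fold lower number from compound 2 to compound 3 (0.56 log units; beyond the scatter), which swaps one aryl group for another on a saturated ring carbon; it is modest but beyond the scatter.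

Compound 4 `O=C1CC(c2ccccn2)CN1c1cnn2c1CN(C(=O)Nc1cc(F)c(F)c(F)c1)C(C1CC1)C2` differs from compound 3 only by hydrogen in place of fluoro on an aromatic carbon. Going by the values given here, no measured pair shows the loss of a fluoro alone, so the step of a 3.6-fold lower number from compound 2 to compound 3 (0.56 log units; beyond the scatter) is only a loose guide to how much a change on this aryl group can move this assay. A small change is therefore expected, most likely no step beyond the scatter, with a slight lean toward a higher number; the expected step is a 1.4-fold higher number from compound 3 to compound 4 (0.15 log units; within the scatter). Compound 4 is estimated at 55000 nM, with a range from 25000 nM to 120000 nM.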

Compound 4, half-maximal cytotoxic concentration: 96200 nM
Estimate against measurement, compound 4: 1.7-fold (0.24 log units) below; the measured number falls inside the stated range.
By their numbers in this assay, from the lowest: compound 3; then compounds 4, 1 and 2 (each within the scatter of the next).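

Taking the fluoro off this aromatic carbon, para to a large group, gives in this assay a 2.5-fold higher number from compound 3 to compound 4 (0.40 log units; beyond the scatter), so this single atom moves the number by a modest step beyond the scatter. Without the fluoro, the two aryl groups no longer stand apart, with a 1.4-fold lower number from compound 2 to compound 4 (0.16 log units; within the scatter); among these compounds, a pyridine ring gives a lower number than the 1,3-oxazol-5-yl group only when it carries the fluoro. The data shown contain no measurement that explains why this atom shifts the tolerated concentration.

From the compounds shown here alone, it remains open whether a different group on the same carbon, such as chloro, methoxy or an amine, would lower the number as fluoro does or leave it near that of compound 4. Going by these compounds, how far the step from fluoro to hydrogen carries over to other versions of the core also remains open.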